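The compounds below may be only part of what the source reports. "The series", "measured", "known", "first", "only" and "open" are said of these compounds alone.

Measured so far in a functional assay on LOX IMVI cells (Homo sapiens) for inhibition, read by sulforhodamine B assay, with a stated time of 48 h; on this read-out higher numbers stand for weaker inhibition of growth and lower numbers for stronger inhibition of growth:

compound 1, `O=C(Nc1cccc(-n2cc(-c3ccncc3)c(-c3ccc(Cl)c(O)c3)n2)c1)Nc1cccc(C(F)(F)F)c1`, gives 2530 nM
compound 2, `COc1cc(-c2nn(-c3cccc(NC(=O)Nc4cc(C(F)(F)F)cc(C(F)(F)F)c4)c3)cc2-c2ccncc2)ccc1Cl`, gives 783 nM
compound 3, `COc1cc(-c2nn(-c3cccc(NC(=O)c4cccc(C(F)(F)F)c4)c3)cc2-c2ccncc2)ccc1Cl`, gives 1390 nM

Compound 1 carries the highest of the three numbers in this assay. Compound 3 stands close to it, within the usual scatter of repeated measurements, so the two cannot be ranked against each other. Compound 2 stands farther off, with a lower number than compound 1 by a margin that lies beyond the scatter.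

Compound 4, `O=C(Nc1cccc(-n2cc(-c3ccncc3)c(-c3ccc(Cl)c(O)c3)n2)c1)Nc1ccc(Cl)c(Cl)c1`, has not yet been measured in this assay. It differs from compound 1 in one place: 3,4-dichlorophenyl in place of 3-(trifluoromethyl)phenyl on an amide-type nitrogen. Within the data shown here, no pair among the measured compounds shows this change on its own, so its effect cannot be read from a measured step; the only guide is the position of compound 1 itself and the fact that the rest of the molecule is kept unchanged.

On that basis the account expects no step beyond the scatter from compound 1 to compound 4, leaning if anything toward a slightly lower number, and the expected step is a 1.3-fold lower number from compound 1 to compound 4 (0.12 log units; within the scatter). Compound 4 is accordingly estimated at 1900 nM, with a plausible range from 700 nM to 5000 nM.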

Compound 4, concentration for 50% growth inhibition: 939 nM
Estimate against measurement, compound 4: 2.0-fold (0.31 log units) above, within the range that was stated.
By their numbers in this assay, from the lowest: compounds 2, 4, 3 and 1 (each within the scatter of the next, the first and the last beyond it).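

With the rest of compound 1 kept unchanged, placing 3,4-dichlorophenyl instead of 3-(trifluoromethyl)phenyl on the amide-type nitrogen gives a 2.7-fold lower number from compound 1 to compound 4 (0.43 log units; beyond the scatter) in this assay. This is the first step at this position among the compounds shown, and it indicates that the group on this nitrogen can, on its own, move the number beyond the scatter, although only modestly, even though both groups keep one six-membered aromatic ring of carbon only. Nothing available explains how this exchange produces the step, so it stands as an observation about this one pair.

Still open is whether the same exchange would give a similar step with a methoxy group in place of the hydroxy group of compound 1, as no pair shown tests the exchange in that setting. Also open, as far as these compounds go, is how an unsubstituted phenyl, a 4-fluorophenyl or a phenyl bearing a carboxylic acid would stand on the same nitrogen, and so whether the step reflects the chlorines, the loss of trifluoromethyl or both.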